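This account rests on a few compounds, and the source may have more. Where it says the series, first, only, none or still open, it means among the compounds named here.

Compound 1 `N/C(=N\NC(=S)N1CCCCCC1)c1ccccn1` gives 56% in a functional assay on MCF7 cells (Homo sapiens) for cytotoxicity, read by MTT assay, with a stated time of 72 h, tested at 3 uM (on this read-out lower numbers stand for less inhibition of growth and higher numbers for more inhibition of growth at the one concentration tested), the highest of the three numbers measured. Compound 3 `Cc1ccnc(/C(N)=N/NC(=S)N2CCCCCC2)c1` gives 36.3%, and compound 2 `Cc1cccc(/C(N)=N/NC(=S)N2CCCCC2)n1` gives 27.1%. Compound 4 `Cc1cccc(/C(N)=N/NC(=S)N2CCCCCC2)n1` differs from compound 1 by methyl in place of hydrogen on an aromatic carbon, a methyl placed next to the ring nitrogen. For the measured compounds named here, the only measured step of the same kind, a methyl added to the ring of compound 1 at a different spot, ran a number 19.7 percentage points lower from compound 1 to compound 3 (beyond the scatter), so a downward step beyond the scatter is expected here too. Compound 2 carries its methyl at the same spot as compound 4 but on a smaller saturated ring, and its value points the same way. The estimate for compound 4 is therefore 34%, between 18% and 52%, a step of a number 22 percentage points lower from compound 1 to compound 4 (beyond the scatter).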

Compound 4, percent growth inhibition at one concentration: 15.7%
Compound 4: the middle estimate sits 18.3 percentage points above what was measured, and the stated range ends above it.
By their numbers in this assay, from the lowest: compound 4; then compounds 2 and 3 (each within the scatter of the next); then compound 1.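

Placing methyl in place of hydrogen next to the ring nitrogen gives, in this assay, a number 40.3 percentage points lower from compound 1 to compound 4 (beyond the scatter). That step is larger than a number 19.7 percentage points lower from compound 1 to compound 3 (beyond the scatter), where the methyl sits elsewhere on the ring, so where this single methyl goes matters and not only its presence. Nothing measured here bears on why this spot gives the larger drop.

On these data alone, whether an ethyl group, a methoxy group or an amine at this spot would also lower the number remains open.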